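A 4-methylphenyl swap on a compound at the limit

The source may report more compounds than this note shows. Statements on the series, on what has been measured and on what is new or still open speak of the compounds shown alone.

In a functional assay on HepG2 cells (Homo sapiens) for cytotoxicity, read by MTT assay, with a stated time of 72 h (on this read-out lower numbers stand for stronger inhibition and higher numbers for weaker inhibition), compound 1 `Cn1cccc1-c1nc2cc(NC(=O)CCCl)ccc2[nH]1` gives > 50000 nM, which is a limit. Compound 2 `CCN1CCN(CC(=O)Nc2ccc3[nH]c(-c4cccn4C)nc3c2)CC1` gives > 50000 nM, also a limit, and so stands at the limit of > 50000 nM in this assay, at which 2 of the 2 values shown sit. Within the data shown here, the only measured step, a step that the two limits leave unreadable from compound 1 to compound 2, lies elsewhere on the molecule and offers no size to carry over. Compound 3 `CCN1CCN(CC(=O)Nc2ccc3[nH]c(-c4ccc(C)cc4)nc3c2)CC1` differs from compound 2 by 4-methylphenyl in place of 1-methyl-1H-pyrrol-2-yl on an aromatic carbon. In this assay only a small move towards stronger inhibition is expected, with the estimated step of an at least 1.2-fold lower number from compound 2 to compound 3 (0.09 log units; that floor lies within the scatter). Compound 3 is estimated at 40000 nM, with an expected range of 12000 nM to 100000 nM.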

Compound 3, half-maximal inhibitory concentration: 31900 nM
Beside the measured number, compound 3's estimate is 1.3-fold (0.10 log units) above it; low and high end bracket the measured number.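

Among these compounds, on this aromatic carbon, 4-methylphenyl in place of 1-methyl-1H-pyrrol-2-yl gives in this assay the only readable step so far: an at least 1.5-fold lower number from compound 2 to compound 3 (0.19 log units; that floor lies within the scatter) is a floor, and it does not establish a gain. Only compound 3 reads as a number among the compounds shown, and the other two remain at a limit: the limit of > 50000 nM in this assay, at which 2 of the 3 values shown sit.

Still open, as far as these compounds go, is whether a phenyl without the methyl, or a phenyl carrying an amine or a carboxylic acid, would move the number beyond the scatter. The compounds shown also leave open how far the 4-ethylpiperazin-1-yl chain contributes once the aryl group is 4-methylphenyl.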